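The source may report more compounds than this note shows. Statements on the series, on what has been measured and on what is new or still open speak of the compounds shown alone.

In an ADME assay on the whole organism (strain CD-1) for metabolic stability, with Mus musculus as the target, at a dose of 3 mg/kg by the intravenous route (on this read-out lower numbers stand for a shorter-lived compound and higher numbers for a longer-lived compound), compound 1 `C[C@@H](CCCOc1ccccc1CN(C)C(=O)c1ccc(-c2ccco2)cc1)CC(=O)O` gives 2 h. Within the data shown here, the only comparison so far is compound 2 `CN(Cc1ccccc1OCCC[C@@H]1C[C@@H]1C(=O)O)C(=O)c1ccc(-c2ccco2)cc1`, which gives 2.7 h. These two numbers lie within the usual scatter of each other, so neither compound can be called the longer-lived.

Compound 3 `C/C(=C\C(=O)O)CCCOc1ccccc1CN(C)C(=O)c1ccc(-c2ccco2)cc1` has not yet been measured. It differs from compound 1 in one place: 2-carboxy-1-methylethenyl in place of 1-(carboxymethyl)ethyl on a saturated chain carbon, three bonds along the chain from an oxygen on an aromatic ring. Put simply, 2-carboxy-1-methylethenyl stands in place of 1-(carboxymethyl)ethyl on a saturated chain carbon, three bonds along the chain from an oxygen on an aromatic ring.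

Among the measured compounds shown here, one measured step bears on this change: a 1.4-fold higher number from compound 1 to compound 2 (0.13 log units; within the scatter). That step replaces the same group at the same place, although a different group, 2-carboxycyclopropyl, enters there. For the measured compounds named here, a single step is thin evidence, and no measurement yet shows what 2-carboxy-1-methylethenyl itself does. Going by the values given here, with only that step to go on, no shift beyond the scatter is expected in this assay, and no direction can be favoured. The expected change is a 1.1-fold higher number from compound 1 to compound 3 (0.04 log units; within the scatter). The estimate for compound 3 is 2.2 h, with an expected range from 1 h to 4.5 h.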

Compound 3, half-life: 1.6 h
Compound 3: middle estimate off by 1.4-fold (0.14 log units), on the high side, and the stated range covers the measured number.
By their numbers in this assay, from the lowest: compounds 3, 1 and 2 (each within the scatter of the next).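

In this assay, putting 2-carboxy-1-methylethenyl in place of 1-(carboxymethyl)ethyl gives a 1.3-fold lower number from compound 1 to compound 3 (0.10 log units; within the scatter) and so adds a second double bond outside the aromatic rings and removes the defined stereocentre without a shift that can be told from the scatter. Against the ring-containing group, the same new group gives a 1.7-fold lower number from compound 2 to compound 3 (0.23 log units; within the scatter) and this step also stays inside the scatter, so all three groups tried on a saturated chain carbon, three bonds along the chain from an oxygen on an aromatic ring, now read alike and none can be called the longer-lived. No measurement is available that would explain these numbers.

On these data alone, all three groups end in a carboxylic acid, so it remains open how a tetrazole or an amine at this place would behave in this assay and whether any group here can move the half-life beyond the scatter. As far as these compounds go, it is also open whether a longer chain between the oxygen and the carboxylic acid, or the other geometry of the double bond in compound 3, would give a number that differs from these.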